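Fluoro for methoxy on the pendant phenyl: para versus ortho

A few compounds are considered here, and "the series" means these few. Any claim that something is new, unique, unknown or untested is made for them only; others in the source may bear on it.

Measured so far:
compound 1 `COc1ccc(-c2cn3ccnc3c(-c3ccc4ncn(C5CCCCC5)c4c3)n2)cc1` -8.48%
compound 2 `Fc1ccc(-c2cn3ccnc3c(-c3ccc4ncn(C5CCCCC5)c4c3)n2)cc1` 24.4%
compound 3 `COc1ccccc1-c1cn2ccnc2c(-c2ccc3ncn(C4CCCCC4)c3c2)n1` 0.95%

In a functional assay on RXF 393 cells (Homo sapiens) for inhibition, read by sulforhodamine B assay, with a stated time of 48 h, tested at 10 uM (on this read-out lower numbers stand for less inhibition and higher numbers for more inhibition at the one concentration tested (going by the name of the read-out)), compound 1 and compound 2 differ by fluoro in place of methoxy on an aromatic carbon. Going by the values given here, that step, a number 32.9 percentage points higher from compound 1 to compound 2 (beyond the scatter), is the only measured instance of the change. The cores of compound 1 and compound 3 differ by 2-methoxyphenyl in place of 4-methoxyphenyl on an aromatic carbon, with a number 9.4 percentage points higher from compound 1 to compound 3 (within the scatter). Compound 2 and compound 3 differ by a number 23.5 percentage points lower from compound 2 to compound 3 (beyond the scatter).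

Compound 4 `Fc1ccccc1-c1cn2ccnc2c(-c2ccc3ncn(C4CCCCC4)c3c2)n1` is not yet measured. It differs from compound 3 by fluoro in place of methoxy on an aromatic carbon. Around the place the group sits ortho to a large group in compound 4, whereas in compound 2 it sits para to a large group, so this is the same kind of change, not the same one.

From compound 3 the step in this assay is expected to be a number 15.1 percentage points higher from compound 3 to compound 4 (beyond the scatter), smaller than the measured rise because a number 32.9 percentage points higher from compound 1 to compound 2 (beyond the scatter) was read at a different place and compound 3 starts from 0.95%. Compound 4 is expected to give 16%, between -8% and 40%.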

Compound 4, a percentage reported as inhibition, at one concentration (the size of the read-out at that concentration, not a potency): 12.3%
For compound 4 the middle estimate is 3.7 percentage points above the measured one, within the range that was stated.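

In this assay, fluoro in place of methoxy gives a higher number on both cores, but the size of the step does not carry over from one core to the other: the same change on two cores in this assay, a number 32.9 percentage points higher (beyond the scatter) from compound 1 to compound 2 and a number 11.4 percentage points higher (beyond the scatter) from compound 3 to compound 4, 21.5 percentage points apart, beyond the scatter of two such steps

The direction holds across the two pairs. The step on the 2-methoxyphenyl pair is a number 11.4 percentage points higher from compound 3 to compound 4 (beyond the scatter), and with fluoro on both sides, 2-fluorophenyl in place of 4-fluorophenyl gives a number 12.1 percentage points lower from compound 2 to compound 4 (beyond the scatter), while the full change from 4-methoxyphenyl to 2-fluorophenyl gives a number 20.8 percentage points higher from compound 1 to compound 4 (beyond the scatter). Two pairs at one concentration do not show why the steps differ in size, nor do they give a rule for the size of this change on any further core.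

The compounds shown leave open whether the same direction would hold for an amine or a carboxylic acid in place of fluoro or methoxy on the phenyl ring. They also leave open how these compounds would rank across a range of concentrations.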